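Swapping the Nitro for a Methoxy on the Benzyl Ether

A few compounds are considered here, and "the series" means these few. Any claim that something is new, unique, unknown or untested is made for them only; others in the source may bear on it.

Compound 3 `COc1cccc(OC)c1OCCNCCOc1ccccc1OCc1cccc([N+](=O)[O-])c1` carries the largest of the three measured numbers, 8.85 in a functional assay on Vas deferens for antagonist activity at Alpha-1A adrenergic receptor (Rattus norvegicus) (on this read-out higher numbers stand for higher potency (the scale is a negative logarithm) and lower numbers for lower potency), though the gap to compound 1 is within the scatter. Compound 1 `COc1cccc(OC)c1OCCNCCOc1ccccc1OCc1ccccc1Cl` gives 8.56, and compound 2 `COc1cccc(OC)c1OCCNCCOc1ccccc1OCc1ccc(C)cc1` gives 8.23. The step of a number 0.29 log units higher from compound 1 to compound 3 (within the scatter) is within the scatter, while a number 0.62 log units higher from compound 2 to compound 3 (beyond the scatter) and a number 0.33 log units lower from compound 1 to compound 2 (beyond the scatter) are modest. Compound 4 `COc1cccc(COc2ccccc2OCCNCCOc2c(OC)cccc2OC)c1` differs from compound 3 by methoxy in place of nitro on an aromatic carbon. Among the measured compounds shown here, no measured step exchanges these two groups directly, so the expectation rests on the modest spread seen among the measured benzyl substituents. For compound 4 the estimate is 8.4, with a range from 7.9 to 8.9. This estimate means an expected step of a number 0.45 log units lower from compound 3 to compound 4 (beyond the scatter), downward and small, with little certainty about whether it will exceed the scatter.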

Compound 4, negative logarithm of the antagonist equilibrium constant: 8.3
Compound 4: middle estimate off by 0.10 log units, on the high side; measured number inside the range.
By their numbers in this assay, from the lowest: compounds 2, 4, 1 and 3 (each within the scatter of the next, the first and the last beyond it).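

This is the only direct exchange shown on this aromatic carbon: methoxy in place of nitro gives a number 0.55 log units lower from compound 3 to compound 4 (beyond the scatter), so the two groups are not interchangeable here. Compound 4 still stays level with the benzyl ethers that carry other substituents, at a number 0.07 log units higher from compound 2 to compound 4 (within the scatter) and a number 0.26 log units lower from compound 1 to compound 4 (within the scatter). Nothing available gives a reason for the step from nitro to methoxy.

Still open, as far as these compounds go, is how the number would move with an amine or a carboxylic acid on the same aromatic carbon. Also open, from the compounds shown here alone, is whether methoxy would give a similar number on another carbon of that ring.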